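Restoring an aryl arm to compound 3

A few compounds are considered here, and "the series" means these few. Any claim that something is new, unique, unknown or untested is made for them only; others in the source may bear on it.

Compound 1 `Nc1cccc(Cn2cc(-c3ccc4cn[nH]c4c3)ccc2=O)c1` — 84 nM
Compound 2 `O=c1ccc(-c2ccc3cn[nH]c3c2)cn1Cc1ccccc1` — 75 nM
Compound 3 `Cn1cc(-c2ccc3cn[nH]c3c2)ccc1=O` — > 2000 nM

In an assay for inhibition of MAP kinase-interacting serine/threonine-protein kinase 2 (Homo sapiens), read by luminescence and ADP-Glo, with a stated time of 2 h (on this read-out lower numbers stand for stronger inhibition and higher numbers for weaker inhibition), compound 1 gives 84 nM and compound 2 gives 75 nM. For compound 3 this assay reports only a limit, > 2000 nM, not a number. Compound 3 therefore sits at the limit of > 2000 nM in this assay, at which 1 of the 3 values shown sits, the weak end of what has been measured.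

Compound 4 `O=c1ccc(-c2ccc3cn[nH]c3c2)cn1Cc1ccc(Cl)c(Cl)c1` has not yet been measured. It differs from compound 3 by 3,4-dichlorophenyl in place of hydrogen on a saturated chain carbon bound to an aromatic nitrogen. Going by the values given here, two measured steps bear directly on this place, both running in the opposite direction: an at least 23-fold higher number from compound 1 to compound 3 (1.37 log units; beyond the scatter) and an at least 26-fold higher number from compound 2 to compound 3 (1.42 log units; beyond the scatter). Both are large. The step between the two aryl-bearing compounds, a 1.1-fold lower number from compound 1 to compound 2 (0.05 log units; within the scatter), shows that a substituent on that aryl ring changed little. The change from compound 3 to compound 4 puts an aryl group back on the same carbon, so a large step toward a lower number in this assay is expected.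

Compound 4 is therefore expected to give about 100 nM in this assay. The expected range for compound 4 runs from 30 nM to 400 nM. This estimate for compound 4 means an at least 20-fold lower number from compound 3 to compound 4 (1.30 log units; beyond the scatter).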

Compound 4, half-maximal inhibitory concentration: 97 nM
Estimate against measurement, compound 4: 1.0-fold (0.01 log units) above, and the stated range covers the measured number.
By their numbers in this assay, from the lowest: compounds 2, 1 and 4 (each within the scatter of the next). At a limit, above all of these: compound 3.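

In this assay, the saturated chain carbon bound to an aromatic nitrogen again proves to be a place where an aryl arm matters, and this now holds for a ring carrying two chlorine atoms, with an at least 20-fold lower number from compound 3 to compound 4 (1.31 log units; beyond the scatter). From the compounds shown here alone, the true size of this step remains unknown, as the value for compound 3 is only a limit: the limit of > 2000 nM in this assay, at which 1 of the 4 values shown sits. Going by these compounds alone, what the earlier compounds could not show is how far the ring can be changed, and the two remaining steps, a 1.3-fold higher number from compound 2 to compound 4 (0.11 log units; within the scatter) and a 1.2-fold higher number from compound 1 to compound 4 (0.06 log units; within the scatter), both lie within the scatter, so 3,4-dichlorophenyl, phenyl and 3-aminophenyl cannot be told apart in this read-out.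

All of these arms are substituted or unsubstituted phenyl rings on that same carbon, so the compounds shown leave open whether a saturated ring such as cyclohexyl, or a longer chain carrying the phenyl ring, would give numbers in the same range. They also leave open whether the insensitivity to ring substituents extends to a charged group such as a carboxylic acid on the ring.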